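Phenyl in Place of Bromine on the Aromatic Ring

This account rests on a few compounds, and the source may have more. Where it says the series, first, only, none or still open, it means among the compounds named here.

Measured compounds in a binding assay on CHO cells for binding affinity to metabotropic glutamate receptor 2 (Rattus norvegicus); on this read-out higher numbers stand for weaker inhibition and lower numbers for stronger inhibition:
compound 1, `N[C@]1(C(=O)O)[C@H]2[C@@H](C[C@H]1OCCCc1ccccc1)[C@]2(F)C(=O)O`, gives 9.83 nM
compound 2, `N[C@]1(C(=O)O)[C@H]2[C@@H](C[C@H]1OCc1ccccc1Cl)[C@]2(F)C(=O)O`, gives 4.99 nM
compound 3, `N[C@]1(C(=O)O)[C@H]2[C@@H](C[C@H]1OCc1cccc(Br)c1)[C@]2(F)C(=O)O`, gives 4.71 nM

Compound 3 holds the lowest of the three numbers in this assay. Its nearest neighbour is compound 2, and the two lie within the scatter of each other (a 1.1-fold lower number from compound 2 to compound 3 (0.03 log units; within the scatter)). Compound 1 stands furthest away, and that gap is modest but beyond the scatter (a 2.1-fold lower number from compound 1 to compound 3 (0.32 log units; beyond the scatter)), while a 2.0-fold lower number from compound 1 to compound 2 (0.29 log units; within the scatter) remains within the scatter.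

Compound 4, `N[C@]1(C(=O)O)[C@H]2[C@@H](C[C@H]1OCc1cccc(-c3ccccc3)c1)[C@]2(F)C(=O)O`, differs from compound 3 in one place: phenyl in place of bromo on an aromatic carbon. Among the measured compounds shown here, no measured step exchanges a halogen on the aromatic ring for a phenyl, so nothing bears on this change directly. For the measured compounds named here, the only step that alters the group on that aromatic ring, a 1.1-fold lower number from compound 2 to compound 3 (0.03 log units; within the scatter), was within the scatter, and the two steps starting from compound 1 were modest at most. The change from compound 3 to compound 4 is therefore expected to give no step beyond the scatter, or a small one in either direction. Compound 4 is estimated at 6 nM, with a range from 2 nM to 20 nM, which corresponds to an expected step of a 1.3-fold higher number from compound 3 to compound 4 (0.11 log units; within the scatter).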

Compound 4, inhibition constant: 9.34 nM
Compound 4: middle estimate off by 1.6-fold (0.19 log units), on the low side, within the range that was stated.
By their numbers in this assay, from the lowest: compounds 3, 2, 4 and 1 (each within the scatter of the next, the first and the last beyond it).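

The exchange gave a 2.0-fold higher number from compound 3 to compound 4 (0.30 log units; within the scatter) in this assay, so this aromatic carbon carries phenyl, with 6 heavy atoms and its own six-membered aromatic ring, as well as it carries bromo, with 1 heavy atom, without a step beyond the scatter. Compounds 2 and 3 had shown only that one halogen can stand in for another on this aromatic ring, each with a single atom on the ring; compound 4 extends that reading to a substituent that is a whole aromatic ring and not a halogen at all. No measurement of any property of these groups is available to account for this result, so the reading remains purely one of the numbers in the binding assay.

What the compounds shown leave open is how this same aromatic carbon would respond to an amine, a carboxylic acid or a longer chain in place of the phenyl, all groups that differ from both bromo and phenyl in kind. They also leave open whether the phenyl would read the same at another carbon of that aromatic ring.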